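Working notes on an aromatic chloro step in a small series

The compounds below may be only part of what the source reports. "The series", "measured", "known", "first", "only" and "open" are said of these compounds alone.

Measured so far:
compound 1 `Cc1nnc(CN)n1-c1ccc(Cl)cc1C(O)c1ccccc1` — 71 mg/kg
compound 2 `Cc1nnc(CN(C)C)n1-c1ccccc1C(=O)c1ccccc1Cl` — > 100 mg/kg
compound 3 `CNCc1nnc(C)n1-c1ccc(Cl)cc1C(=O)c1ccccc1` — 63 mg/kg

In a functional assay on the whole organism (strain CF-1) for inhibition, with Mus musculus as the target (a higher number here means that more compound is needed for the effect, a lower number that less compound is needed), compound 1 gives 71 mg/kg and compound 3 gives 63 mg/kg; these two numbers lie within the usual scatter of each other, so no order between them is claimed. Compound 2 stands apart: in this assay compound 2 gives only > 100 mg/kg, which is a limit of the assay and not a number. This is the limit of > 100 mg/kg in this assay, at which 1 of the 3 values shown sits.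

The unmeasured compound 4 `Cc1nnc(CN(C)C)n1-c1ccc(Cl)cc1C(=O)c1ccccc1Cl` is compound 2 with one change: chloro in place of hydrogen on an aromatic carbon. Among the measured compounds shown here, no pair of measured compounds differs in exactly this way, so the size of this step has not been measured. Compound 1 and compound 3 both carry chloro at such a carbon and give numbers rather than limits in this assay, whereas compound 2 lacks it and gives only a limit. On that basis a step toward less compound needed is expected for compound 4, of uncertain size, and possibly not beyond the scatter.

Compound 4 is estimated at 90 mg/kg, with a range from 40 mg/kg to 200 mg/kg. This estimate means an expected step of an at least 1.1-fold lower number from compound 2 to compound 4 (0.04 log units; that floor lies within the scatter).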

Compound 4, dose for half-maximal effect: 50 mg/kg
For compound 4 the middle estimate is 1.8-fold (0.26 log units) above the measured one; measured number inside the range.
By their numbers in this assay, from the lowest: compounds 4, 3 and 1 (each within the scatter of the next). At a limit, above all of these: compound 2.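

In this assay, chloro in place of hydrogen on an aromatic carbon, para to a large group and meta to a group of 9 heavy atoms, gives an at least 2.0-fold lower number from compound 2 to compound 4 (0.30 log units; that floor lies within the scatter). With chloro at this carbon, compound 4 gives a number, 50 mg/kg, so this change now rests on a single matched pair rather than on a comparison with compound 1 and compound 3, each of which differs from compound 2 in more than one place. The printed size is only a floor, and the full size of the step cannot be read, because the starting point of the pair is a limit and not a number: the limit of > 100 mg/kg in this assay, at which 1 of the 4 values shown sits.

Going by these compounds, whether another group at this carbon, such as fluoro, bromo, methoxy or trifluoromethyl, would give a similar step remains open. Also open, on these data alone, is whether chloro here has a comparable effect when the basic side chain is a longer chain or a cyclic amine such as morpholine, since one pair supports no pattern across the series.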